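The compounds below may be only part of what the source reports. "The series", "measured", "known", "first", "only" and "open" are said of these compounds alone.

Values so far in a functional assay on KB cells (Homo sapiens) for cytotoxicity; on this read-out lower numbers stand for stronger inhibition and higher numbers for weaker inhibition
compound 1 `COc1ccc(S(=O)(=O)N2CCc3cccc(NC(=O)c4ccc(F)cc4)c32)cc1` gives 93 nM
compound 2 `COc1ccc(S(=O)(=O)N2CCc3cccc(NS(=O)(=O)c4ccccc4)c32)cc1` gives 650 nM
compound 3 `COc1ccc(S(=O)(=O)N2CCc3cccc(NC(=O)c4ccco4)c32)cc1` gives 9.6 nM

Compound 3 has the lowest number of the three, and its steps to both others lie beyond the scatter. The next compound to read is compound 4 `COc1ccc(C(=O)Nc2cccc3c2N(S(=O)(=O)c2ccc(OC)cc2)CC3)cc1` with the change (4-methoxyphenyl in place of furan-2-yl on a carbonyl carbon), that is, 4-methoxyphenyl in place of furan-2-yl on a carbonyl carbon.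

The closest measured evidence is a 9.7-fold lower number from compound 1 to compound 3 (0.99 log units; beyond the scatter), a modest step at the same place with furan-2-yl entering in place of 4-fluorophenyl. The larger 68-fold lower number from compound 2 to compound 3 (1.83 log units; beyond the scatter) also changes the carbonyl itself, so it bears less directly. Going by the values given here, no measured compound carries 4-methoxyphenyl, so its difference from 4-fluorophenyl is unknown.

A modest rise in this assay is therefore expected, roughly reversing the step from compound 1. The expected change is a 9.4-fold higher number from compound 3 to compound 4 (0.97 log units; beyond the scatter) in this read-out. For compound 4 the estimated value is 90 nM, with an expected range of 25 nM to 300 nM.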

Compound 4, half-maximal inhibitory concentration: 2600 nM
For compound 4 the middle estimate is 29-fold (1.46 log units) below the measured one, and the stated range ends below it.
By their numbers in this assay, from the lowest: compound 3; then compound 1; then compound 2; then compound 4.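

In this assay, going by these compounds alone, the group on the carbonyl carbon matters more than the earlier compounds showed, with a 270-fold higher number from compound 3 to compound 4 (2.43 log units; beyond the scatter) standing as the largest step. Methoxy in place of fluoro on an aromatic carbon alone gives a 28-fold higher number from compound 1 to compound 4 (1.45 log units; beyond the scatter) in this comparison, so the two six-membered aromatic rings on this carbonyl are not interchangeable. The carbonyl also no longer ranks ahead of phenylsulfonyl in every case, since a 4.0-fold higher number from compound 2 to compound 4 (0.60 log units; beyond the scatter) goes against compound 1 and compound 3, which both give lower numbers than compound 2.

From the compounds shown here alone, whether an amine or a hydroxyl in place of the methoxy, or a thiophene in place of the furan-2-yl, would keep the low number of compound 3 stays open. Nothing measured here accounts for these differences.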